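The compounds below may be only part of what the source reports. "The series", "measured", "known", "first", "only" and "open" are said of these compounds alone.

In a functional assay on MDA-MB-231 cells (Homo sapiens) for inhibition, read by sulforhodamine B assay, with a stated time of 48 h, tested at 100 uM; on this read-out lower numbers stand for a stronger effect and higher numbers for a weaker effect at the one concentration tested:
compound 1 `COc1cc(Cl)cc(-c2nn(-c3cccc(NC(=O)Nc4ccc(Cl)c(C(F)(F)F)c4)c3)cc2-c2ccncc2)c1` gives -88%
compound 2 `COc1cc(Cl)cc(-c2nn(-c3cccc(NC(=O)Nc4ccc(Cl)c(Cl)c4)c3)cc2-c2ccncc2)c1` gives -70%

Going by the values given here, of these two numbers compound 2 stands highest, the weaker effect, with compound 1 as its only neighbour. Compound 3 `COc1cc(Cl)cc(-c2nn(-c3cccc(NC(=O)Nc4cccc(C(F)(F)F)c4)c3)cc2-c2ccncc2)c1` is not yet measured; it differs from compound 2 by 3-(trifluoromethyl)phenyl in place of 3,4-dichlorophenyl on an amide-type nitrogen, the group sitting on an amide-type nitrogen whose other neighbour is a carbonyl carbon. Among the compounds with values here, the one step that bears on this is a number 18 percentage points higher from compound 1 to compound 2 (beyond the scatter), which moved the number toward weaker effect when a chloro replaced a trifluoromethyl. Returning a trifluoromethyl, though at a different ring position and without the second chloro, is therefore expected to give a modest step toward stronger effect, a number 8 percentage points lower from compound 2 to compound 3 (within the scatter), in this assay. Compound 3 is estimated at -78%, within -95% to -60%.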

Compound 3, a percentage reported as activity, at one concentration (the size of the read-out at that concentration, not a potency): -43%
Compound 3: middle estimate off by 35 percentage points, on the low side; the whole stated range lies below it.
By their numbers in this assay, from the lowest: compound 1; then compound 2; then compound 3.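

In this assay the aryl group on the amide-type nitrogen proves sensitive to its full substitution, not just to the choice of chloro or trifluoromethyl: 3-(trifluoromethyl)phenyl in place of 3,4-dichlorophenyl gives a number 27 percentage points higher from compound 2 to compound 3 (beyond the scatter) toward weaker effect. Hydrogen in place of chloro gives a number 45 percentage points higher from compound 1 to compound 3 (beyond the scatter) also toward weaker effect, so with trifluoromethyl kept, the effect depends heavily on that chloro. On these data alone, whether a methyl, methoxy or nitrile could stand in for that chloro and hold the effect remains open. No measurement here explains these steps.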